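This account rests on a few compounds, and the source may have more. Where it says the series, first, only, none or still open, it means among the compounds named here.

Measured in a physicochemical assay for solubility, read by spectrophotometry, using the shake flask method, with a stated time of 48 h, at pH 6.5; on this read-out lower numbers stand for lower solubility and higher numbers for higher solubility:
- compound 1 `O=C(O)Cn1ccc2ccc(-c3cn(-c4ccc(O)c(F)c4)nn3)nc2c1=O`: 288 ug/mL
- compound 2 `Oc1ccc(-n2cc(-c3ccc4ccccc4n3)nn2)cc1`: 2.2 ug/mL

Compound 2, at 2.2 ug/mL, is the lower of the two numbers. Compound 1 stands far higher at 288 ug/mL, a gap well beyond the usual scatter of this assay. The two compounds differ in more than one place, so this gap does not isolate any single change.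

Compound 3 `NCCOc1ccc2nc(-c3cn(-c4ccc(O)cc4)nn3)ccc2c1` keeps the core of compound 2 and has 2-aminoethoxy in place of hydrogen on an aromatic carbon of a six-membered aromatic ring of carbon only (2-aminoethoxy in place of hydrogen on an aromatic carbon). Going by the values given here, no single-change step has been measured, so the size of the move is a judgement. A rise beyond the scatter in this assay is expected, an estimated 18-fold higher number from compound 2 to compound 3 (1.26 log units; beyond the scatter). Compound 1 gives 288 ug/mL, and compound 3 is expected to remain the lower of the two. The estimate for compound 3 is 40 ug/mL, with an expected range of 10 ug/mL to 150 ug/mL.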

Compound 3, solubility: 3.7 ug/mL
The estimate for compound 3 lay 11-fold (1.03 log units) above the measured number; the whole stated range lies above it.
By their numbers in this assay, from the lowest: compounds 2 and 3 (each within the scatter of the next); then compound 1.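

In this assay, going by these compounds alone, 2-aminoethoxy in place of hydrogen on this aromatic carbon gives the first single-place step (a 1.7-fold higher number from compound 2 to compound 3 (0.23 log units; within the scatter)). At this position, on the ring of carbon only, the read-out therefore does not separate the 2-aminoethoxy chain from hydrogen, so this one change does not move compound 3 clear of compound 2. No supporting measurement is available to explain this result.

The compounds shown leave open whether a longer chain or a dimethylamino group at the end of the chain, placed on this same carbon, would give a step beyond the scatter. They also leave open whether 2-aminoethoxy would read the same on another carbon of that ring.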